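Substituted aryl variants on the shared core: inhibition notes

This account rests on a few compounds, and the source may have more. Where it says the series, first, only, none or still open, it means among the compounds named here.

Measured so far:
- compound 1, `c1ccc(-c2cn3ccnc3c(-c3ccc4ncn(C5CCCCC5)c4c3)n2)cc1`, in a functional assay on HCT-116 cells (Homo sapiens) for inhibition, read by sulforhodamine B assay, with a stated time of 48 h, tested at 10 uM (on this read-out lower numbers stand for less inhibition and higher numbers for more inhibition at the one concentration tested (going by the name of the read-out)), gives 59.5%
- compound 2, `CC(=O)c1ccc(-c2cn3ccnc3c(-c3ccc4ncn(C5CCCCC5)c4c3)n2)cc1`, gives 15.9%
- compound 3, `Clc1ccc(-c2cn3ccnc3c(-c3ccc4ncn(C5CCCCC5)c4c3)n2)cc1`, gives 7.34%

Compound 3 is the lowest of the three numbers; compound 2 lies nearest, within the scatter, and compound 1 furthest, beyond it. Compound 4, `FC(F)(F)c1cccc(-c2cn3ccnc3c(-c3ccc4ncn(C5CCCCC5)c4c3)n2)c1`, differs from compound 3 by 3-(trifluoromethyl)phenyl in place of 4-chlorophenyl on an aromatic carbon. Going by the values given here, no measured step covers this exact swap. Among the compounds with values here, the steps that bear on it are a number 43.6 percentage points lower from compound 1 to compound 2 (beyond the scatter) and a number 52.2 percentage points lower from compound 1 to compound 3 (beyond the scatter), both large drops once the phenyl carries a group, while a number 8.6 percentage points lower from compound 2 to compound 3 (within the scatter) stays within the scatter. A substituted phenyl therefore is expected to leave this assay near the low end, with no step beyond the scatter. Compound 4 is estimated at 12%, range 1% to 30%. The step this estimate implies is expected to be a number 4.7 percentage points higher from compound 3 to compound 4 (within the scatter).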

Compound 4, a percentage reported as inhibition, at one concentration (the size of the read-out at that concentration, not a potency): 17.6%
Estimate against measurement, compound 4: 5.6 percentage points below; the measured number falls inside the stated range.
By their numbers in this assay, from the lowest: compounds 3, 2 and 4 (each within the scatter of the next, the first and the last beyond it); then compound 1.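

In this assay, going by these compounds alone, 3-(trifluoromethyl)phenyl gives a number 10.3 percentage points higher from compound 3 to compound 4 (beyond the scatter), the first step beyond the scatter among the substituted phenyls, while a number 1.7 percentage points higher from compound 2 to compound 4 (within the scatter) shows no separation from the 4-acetylphenyl variant. The unsubstituted phenyl stays apart, with a number 41.9 percentage points lower from compound 1 to compound 4 (beyond the scatter), so the large drop on substitution holds for this group as well as for chloro and acetyl. No measured property is available to explain these steps.

Open, from the compounds shown here alone, is whether an amine or a carboxylic acid on the phenyl would bring the number back towards that of compound 1. The effect of where the group sits also stays unresolved, since compound 3 and compound 4 differ in both the group and its place.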